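A few compounds are considered here, and "the series" means these few. Any claim that something is new, unique, unknown or untested is made for them only; others in the source may bear on it.

Compound 1, `CC(C)CNc1nc(N)nc2c1ncn2/C=C1/CC1(CO)CO`: in an ADME assay on HFF cells (Homo sapiens) for cytotoxicity, with a stated time of 8 days (on this read-out lower numbers stand for higher toxicity in this test and higher numbers for lower toxicity in this test), compound 1 gives > 300000 nM, which is a limit of the assay and not a number.
Compound 2, `CCCOc1nc(N)nc2c1ncn2/C=C1/CC1(CO)CO`: in this assay compound 2 gives > 300000 nM, again a limit of the assay.
Compound 3, `Nc1nc(SC2CCCC2)c2ncn(/C=C3/CC3(CO)CO)c2n1`: in this assay compound 3 gives > 300000 nM, also a limit of the assay.

Among the compounds with values here, compound 3 therefore stands where every measured compound stands: at the limit of > 300000 nM in this assay, at which 3 of the 3 values shown sit, so no compound can be ranked against another, and none is called more or less toxic.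

Compound 4 is `C=CCOc1nc(N)nc2c1ncn2/C=C1/CC1(CO)CO`. It differs from compound 3 in one place: allyloxy in place of cyclopentylsulfanyl on an aromatic carbon.

Within the data shown here, two measured steps touch the same position. The step that the two limits leave unreadable from compound 2 to compound 3 exchanged one of the two groups involved here, and the step that the two limits leave unreadable from compound 1 to compound 3 also ended at the cyclopentylsulfanyl of compound 3. Both sit entirely at the limit, so neither tells how large a change at this position is in this assay. With nothing readable, no step beyond the scatter is expected in either direction.

Compound 4 is expected to return the same limit, so its estimated value is 300000 nM, between 150000 nM and 600000 nM, which means an expected step of a number no higher from compound 3 to compound 4 (the limit leaves the size open).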

Compound 4, half-maximal cytotoxic concentration: > 300000 nM
Compound 4 was reported as a limit (the forecaster's own chance of this, stated with the estimate: 85%); the middle value lies on the limit itself.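

The steps linking compound 4 with compound 1, compound 2 and compound 3 cannot be read, because all four compounds give only a limit of the assay: the limit of > 300000 nM in this assay, at which 4 of the 4 values shown sit.

The compounds shown leave open whether any change at this position alters toxicity in this assay.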